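The source may report more compounds than this note shows. Statements on the series, on what has been measured and on what is new or still open speak of the compounds shown alone.

The measured compounds and their values:

compound 1 `O=C(CSc1nnc(-c2ccncc2)o1)N/N=C/c1ccc(O)cc1` — 5510 nM
compound 2 `COc1ccc(/C=N/NC(=O)CSc2nnc(-c3ccncc3)o2)cc1` — 15800 nM
compound 3 `O=C(CSc1nnc(-c2ccncc2)o1)N/N=C/c1cc(Br)ccc1O` — 6490 nM

In a functional assay on HepG2 cells (Homo sapiens) for cytotoxicity, read by MTT assay, with a stated time of 48 h (a higher number here means a weaker inhibitor, a lower number a stronger inhibitor), compound 1 gives the lowest of the three numbers. Its nearest neighbour is compound 3, reached by a 1.2-fold higher number from compound 1 to compound 3 (0.07 log units; within the scatter), and its furthest is compound 2, reached by a 2.9-fold higher number from compound 1 to compound 2 (0.46 log units; beyond the scatter).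

Compound 4 `O=C(CSc1nnc(-c2ccncc2)o1)N/N=C/c1ccc(Cl)cc1Cl` has not yet been measured. It differs from compound 1 in one place: 2,4-dichlorophenyl in place of 4-hydroxyphenyl on a carbon with a double bond to nitrogen. Among the measured compounds shown here, two measured steps bear on this. The step of a 2.9-fold higher number from compound 1 to compound 2 (0.46 log units; beyond the scatter) shows that covering the hydroxyl with methyl at this phenyl group raised the number modestly. The step of a 1.2-fold higher number from compound 1 to compound 3 (0.07 log units; within the scatter) shows that exchanging the whole phenyl group for a different substituted one left the number within the scatter. Compound 4 likewise loses the hydroxyl and carries a different substitution pattern, so a modest rise in the number, in the direction seen for compound 2, is expected, with a real chance of no change beyond the scatter.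

Compound 4 is therefore estimated at 9500 nM (range 4000 nM to 22000 nM), which is expected to amount to a 1.7-fold higher number from compound 1 to compound 4 (0.24 log units; within the scatter).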

Compound 4, half-maximal inhibitory concentration: 18600 nM
Compound 4: the middle estimate sits 2.0-fold (0.29 log units) below what was measured, within the range that was stated.
By their numbers in this assay, from the lowest: compounds 1 and 3 (each within the scatter of the next); then compounds 2 and 4 (each within the scatter of the next).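

In this assay, replacing the 4-hydroxyphenyl group with 2,4-dichlorophenyl gives a 3.4-fold higher number from compound 1 to compound 4 (0.53 log units; beyond the scatter), and replacing the 5-bromo-2-hydroxyphenyl group gives a 2.9-fold higher number from compound 3 to compound 4 (0.46 log units; beyond the scatter), whereas replacing the 4-methoxyphenyl group gives a 1.2-fold higher number from compound 2 to compound 4 (0.07 log units; within the scatter). Across these four compounds, the two with a hydroxyl on the phenyl group have the lower numbers and the two without one have the higher numbers, with no compound going against this; the bromine of compound 3 also shows that a halogen on this phenyl group does not by itself go with a higher number. Nothing available explains this grouping.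

From the compounds shown here alone, it remains open whether a phenyl group carrying an amine or a carboxylic acid would fall with compounds 1 and 3 or with compounds 2 and 4. A phenyl group with a single chlorine would show whether one halogen gives the same result as two.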